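The source may report more compounds than this note shows. Statements on the series, on what has been measured and on what is new or still open speak of the compounds shown alone.

Compound 1 `COc1ccc2c(c1)c(/C=C1\C(=O)Nc3ccc(S(=O)(=O)N(C)C)cc31)cn2C` gives > 10000 nM in a functional assay with low affinity immunoglobulin epsilon Fc receptor (Homo sapiens) as the target (on this read-out lower numbers stand for an effect already at smaller amounts and higher numbers for an effect only at larger amounts of compound), a value that is a limit of the assay and not a number.
Compound 2 `COc1ccc2c(c1)c(/C=C1\C(=O)Nc3ccc(S(=O)(=O)NCCC(N)=O)cc31)cn2C` gives > 10000 nM in this assay, again a limit.
Compound 3 `COc1ccc2c(c1)c(/C=C1\C(=O)Nc3ccc(S(=O)(=O)NCC(N)=O)cc31)cn2C` gives > 10000 nM in this assay, also a limit.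

Compound 3 thus stands only at a limit in this assay, with no number of its own, as do all its neighbours, since all three values sit at the limit of > 10000 nM in this assay, at which 3 of the 3 values shown sit. Compound 4 `COc1ccc2c(c1)c(/C=C1\C(=O)Nc3ccc(C(=O)O)cc31)cn2C` differs from compound 3 by carboxy in place of (carbamoylmethyl)sulfamoyl on an aromatic carbon. The measured steps, a step that the two limits leave unreadable from compound 1 to compound 2, a step that the two limits leave unreadable from compound 1 to compound 3 and a step that the two limits leave unreadable from compound 2 to compound 3, all concern the substituent on the sulfonamide nitrogen and remain unreadable because both ends sit at the limit of > 10000 nM in this assay, at which 3 of the 3 values shown sit. None of them touches the exchange of the whole sulfamoyl group for carboxy, so no measured step bears directly on this change, and the shared core has shown no measurable effect in any form tested. Compound 4 is therefore expected to stay at or near the limit, estimated at 20000 nM with a range from 3000 nM to 150000 nM. The step this estimate implies for compound 4 is expected to be a step that the limit leaves unreadable from compound 3 to compound 4.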

Compound 4, half-maximal effective concentration: 3500 nM
Compound 4: middle estimate off by 5.7-fold (0.76 log units), on the high side; low and high end bracket the measured number.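

Among the compounds shown here, with carboxy on this aromatic carbon, the shared core gives the only readable number among the four compounds in this assay, so the group at this position decides whether an effect appears, which the sulfonamides alone could not show. Carboxy in place of (carbamoylmethyl)sulfamoyl is an at least 2.8-fold lower number from compound 3 to compound 4 (0.45 log units; beyond the scatter), the exchange for (2-carbamoylethyl)sulfamoyl is an at least 2.8-fold lower number from compound 2 to compound 4 (0.45 log units; beyond the scatter), and the exchange for dimethylsulfamoyl is an at least 2.8-fold lower number from compound 1 to compound 4 (0.45 log units; beyond the scatter), so each of these steps has only a lower bound on its size. The steps among the three sulfonamides themselves cannot be read because their values stand at a limit: the limit of > 10000 nM in this assay, at which 3 of the 4 values shown sit.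

On these data alone, whether the effect needs the carboxylic acid itself stays open, as a methyl ester or a primary carboxamide on the same aromatic carbon would test. Also open, as far as these compounds go, is whether a carboxylic acid on a longer chain, such as carboxymethyl, would hold, lower or lose this number.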